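The compounds below may be only part of what the source reports. "The series", "measured", "known", "first", "only" and "open" are said of these compounds alone.

Compound 3 (`C/C(=C\CC/C(C)=C/CC[C@@H]1[C@@]2(C)CCC(=O)C(C)(C)[C@H]2CC[C@@]1(C)O)CC/C=C(\C)C(=O)OCc1cn(-c2ccccc2C)nn1`) gives > 150000 nM in a functional assay on A549 cells (Homo sapiens) for antiproliferative activity, read by MTT assay, with a stated time of 48 h (a higher number here means a weaker inhibitor, a lower number a stronger inhibitor), as a limit of the assay and not a number. Compound 1 (`C/C(=C\CC/C(C)=C/CC[C@@H]1[C@@]2(C)CCC(=O)C(C)(C)[C@H]2CC[C@@]1(C)O)CC/C=C(\C)C(=O)OCc1cn(-c2ccccc2Br)nn1`) gives > 150000 nM in this assay as a limit too. Compound 2 (`C/C(=C\CC/C(C)=C/CC[C@@H]1[C@@]2(C)CCC(=O)C(C)(C)[C@H]2CC[C@@]1(C)O)CC/C=C(\C)C(=O)OCc1cn(-c2ccc(F)c(Cl)c2)nn1`) gives > 150000 nM in this assay as a limit too. Compound 3 thus stands at the limit of > 150000 nM in this assay, at which 3 of the 3 values shown sit, and offers no number to start from.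

Among the compounds with values here, compound 4 (`C/C(=C\CC/C(C)=C/CC[C@@H]1[C@@]2(C)CCC(=O)C(C)(C)[C@H]2CC[C@@]1(C)O)CC/C=C(\C)C(=O)OCc1cn(-c2ccccc2)nn1`) carries hydrogen in place of methyl on an aromatic carbon, ortho to a large group, as its only change from compound 3 (hydrogen in place of methyl on an aromatic carbon). The closest measured change is a step that the two limits leave unreadable from compound 1 to compound 3 and the other two are a step that the two limits leave unreadable from compound 1 to compound 2 and a step that the two limits leave unreadable from compound 2 to compound 3 with no size to read in any of them. These steps give no ground for expecting a step beyond the scatter in this assay in either direction. The expected change is a number no higher from compound 3 to compound 4 (the limit leaves the size open) and it has no expected direction. Compound 4 is expected near 150000 nM with an estimated range from 60000 nM to 300000 nM and will most likely read again as a limit.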

Compound 4, half-maximal inhibitory concentration: > 150000 nM
Compound 4 ended at the assay's limit (the forecaster's own chance of this, stated with the estimate: 80%); the middle value sits exactly at the limit.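

No step can be read between compound 4 and compound 1, compound 2 or compound 3 in this assay, as all sit at one limit: the limit of > 150000 nM in this assay, at which 4 of the 4 values shown sit.

The compounds shown leave open how far each lies beyond that limit, and whether any substituent on the phenyl group would give a readable number.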